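A few compounds are considered here, and "the series" means these few. Any claim that something is new, unique, unknown or untested is made for them only; others in the source may bear on it.

Of the compounds shown here, two built on a shared core have been measured in a functional assay on the whole organism (strain CF-1 albino) with Mus musculus as the target, with a stated time of 4 h; a higher number here means that more compound is needed for the effect, a lower number that less compound is needed. Compound 1 `O=C1CC(c2ccccc2F)C(=O)N1CN1CCN(c2cccc(C(F)(F)F)c2)CC1` gives 100 mg/kg in this assay, while compound 2 `O=C1CC(c2ccccc2Br)C(=O)N1CN1CCN(c2ccccc2Cl)CC1` gives 300 mg/kg, the higher of the two numbers, and the gap between them lies beyond the usual scatter. Compound 3 `O=C1CC(c2ccccc2Br)C(=O)N1CN1CCN(c2cccc(C(F)(F)F)c2)CC1` has not yet been measured. It differs from compound 2 in one place: 3-(trifluoromethyl)phenyl in place of 2-chlorophenyl on an amine nitrogen in a ring. Since compound 1 carries that same entering group and gives 100 mg/kg, the expected step is a downward one, a 2.0-fold lower number from compound 2 to compound 3 (0.30 log units; within the scatter). For compound 3 the estimate in this assay is 150 mg/kg, within a range from 60 mg/kg to 400 mg/kg.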

Compound 3, minimum effective dose: 300 mg/kg
Estimate against measurement, compound 3: 2.0-fold (0.30 log units) below; measured number inside the range.
By their numbers in this assay, from the lowest: compound 1; then compounds 2 and 3 (each within the scatter of the next).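

With bromo in place, 3-(trifluoromethyl)phenyl in place of 2-chlorophenyl on the amine nitrogen in the ring gives, in this assay, no change at the digits printed from compound 2 to compound 3 (within the scatter) and stays within the scatter. Going by these compounds alone, with 3-(trifluoromethyl)phenyl held constant, bromo in place of fluoro on an aromatic carbon gives a 3.0-fold higher number from compound 1 to compound 3 (0.48 log units; beyond the scatter) and so provides the first single-place step beyond the scatter. No available data explain either step.

Going by these compounds, whether the bromo-for-fluoro step holds with 2-chlorophenyl on the ring nitrogen remains open. So does the result with chloro or methoxy on that aromatic carbon.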